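Thiazolyl for thienyl on the shared core of compound 2

A few compounds are considered here, and "the series" means these few. Any claim that something is new, unique, unknown or untested is made for them only; others in the source may bear on it.

In an assay on CFBE41o cells with Cystic fibrosis transmembrane conductance regulator variant F508del (Homo sapiens) as the target, with a stated time of 24 h (on this read-out lower numbers stand for an effect already at smaller amounts and higher numbers for an effect only at larger amounts of compound), compound 2 `CSc1cccc(Nc2nc(-c3cccs3)cs2)c1` gives 8500 nM, the highest of the two numbers recorded. Its nearest neighbour, compound 1 `CSc1cccc(Nc2nc(-c3cccc(Cl)c3)cs2)c1`, gives 5300 nM, and a 1.6-fold higher number from compound 1 to compound 2 (0.21 log units; within the scatter) lies within the scatter. Compound 3 `CSc1cccc(Nc2nc(-c3nccs3)cs2)c1` differs from compound 2 by 1,3-thiazol-2-yl in place of thiophen-2-yl on an aromatic carbon. Among the measured compounds shown here, the only measured step, a 1.6-fold higher number from compound 1 to compound 2 (0.21 log units; within the scatter), concerns a different exchange at this position and stayed within the scatter, so no step beyond the scatter is expected. For compound 3 the expected step is no change at the digits printed from compound 2 to compound 3 (within the scatter). Compound 3 is therefore estimated at 8500 nM, between 3000 nM and 25000 nM.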

Compound 3, half-maximal effective concentration: "not active" (no number reported)
For compound 3 the study gives words and no number; the estimate stays without a comparison.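

Among the compounds shown here, compound 3 is reported in words, without a number, so no step from compound 2 to compound 3 can be read. No measured evidence explains this result. The compounds shown leave open how far 1,3-thiazol-2-yl shifts the read-out relative to thiophen-2-yl.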